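The compounds below may be only part of what the source reports. "The series", "measured", "known", "first", "only" and "open" are said of these compounds alone.

Compound 1 (`COc1ccc(-c2ncnn2-c2cc(OC)c(OC)c(OC)c2)cc1`) gives 120 nM
Compound 2 (`COc1cc(-n2ncnc2-c2cccc([N+](=O)[O-])c2)cc(OC)c1OC`) gives > 10000 nM

Both values come from a functional assay on HL-60 cells (Homo sapiens) for antiproliferative activity, read by MTT assay, with a stated time of 72 h (on this read-out higher numbers stand for weaker inhibition and lower numbers for stronger inhibition), and were obtained under the same conditions. For compound 2 the result, > 10000 nM, is only a limit of the assay and not a number. Compound 3 (`COc1cc(-n2ncnc2-c2cccc(Cl)c2)cc(OC)c1OC`) has chloro in place of nitro on an aromatic carbon, meta to a large group (chloro in place of nitro on an aromatic carbon). For the measured compounds named here, no measured step isolates this change. Compound 1, at 120 nM in this assay, shows that strong inhibition is possible with the shared core. A move toward stronger inhibition is therefore expected, with an estimated at least 6.6-fold lower number from compound 2 to compound 3 (0.82 log units; beyond the scatter) in this assay, although a second limit remains possible. For compound 3 the estimated value is 1500 nM, with an expected range of 150 nM to 10000 nM in this assay.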

Compound 3, half-maximal inhibitory concentration: > 10000 nM
Compound 3: only a limit was reported (the forecaster's own chance of this, stated with the estimate: 35%); middle value at least 6.6-fold (0.82 log units) away from the limit.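

In this assay compound 3 gives > 10000 nM, which is a limit of the assay and not a number. With chloro in place of nitro on this aromatic carbon, the result stays at the same limit, so the step between the two compounds cannot be read: the limit of > 10000 nM in this assay, at which 2 of the 3 values shown sit. Taking 3-chlorophenyl in place of 4-methoxyphenyl gives an at least 83-fold higher number from compound 1 to compound 3 (1.92 log units; beyond the scatter), so chloro at this place does not restore the strong inhibition seen with the shared core. On these data alone, it remains open whether an amine or a hydroxyl on this carbon would give a readable value. As far as these compounds go, it also remains open whether the loss follows from the place of the substituent or from the absence of the methoxy group.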